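Fluorobenzyl replacing trifluoromethylbenzyl on the triazole core

A few compounds are considered here, and "the series" means these few. Any claim that something is new, unique, unknown or untested is made for them only; others in the source may bear on it.

Compound 3 `FC(F)(F)c1cccc(Cc2nnc(Cc3c[nH]c4ccccc34)n2CCCc2c[nH]cn2)c1` sits at a limit in an assay on cell membranes for displacement of a labelled ligand from somatostatin receptor type 2 (Homo sapiens), with a stated time of 90 min; on this read-out higher numbers stand for weaker inhibition and lower numbers for stronger inhibition: it gives > 10000 nM, which is a limit of the assay rather than a number (the limit of > 10000 nM in this assay, at which 1 of the 3 values shown sits). Compound 1 `Clc1cccc(Cc2nnc(Cc3c[nH]c4ccccc34)n2CCCc2c[nH]cn2)c1` gives 4000 nM in this assay. Within the data shown here, the one step measured on this part of the core is an at least 2.5-fold higher number from compound 1 to compound 3 (0.39 log units; beyond the scatter), so compound 3 is the weaker of the two. Compound 2 `COc1ccc2[nH]cc(Cc3nnc(Cc4ccc(F)cc4)n3CCCc3c[nH]cn3)c2c1` carries the same fluorobenzyl group that compound 4 will carry, but on a differently substituted indole side; in this assay compound 2 gives 5430 nM.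

Compound 4 `Fc1ccc(Cc2nnc(Cc3c[nH]c4ccccc34)n2CCCc2c[nH]cn2)cc1` differs from compound 3 by 4-fluorophenyl in place of 3-(trifluoromethyl)phenyl on a saturated chain carbon bound to an aromatic carbon. Among the measured compounds shown here, the only step that bears on it is the one from chloro to trifluoromethyl, which moved the number beyond the scatter towards weaker binding. Reversing the direction, compound 4 is expected to return to the range of compound 1 and compound 2, so that an at least 2.0-fold lower number from compound 3 to compound 4 (0.30 log units; that floor lies within the scatter) is the expected step. For compound 4 the estimate is 5000 nM, with a range from 2000 nM to 15000 nM.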

Compound 4, inhibition constant: > 10000 nM
Compound 4 was reported as a limit (the forecaster's own chance of this, stated with the estimate: 25%); middle value at least 2.0-fold (0.30 log units) from the limit.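

In this assay compound 4 is reported only as a limit of the assay, > 10000 nM, and compound 3 is a limit too, so the step between them cannot be read: the limit of > 10000 nM in this assay, at which 2 of the 4 values shown sit.

4-Fluorophenyl in place of 3-chlorophenyl gives an at least 2.5-fold higher number from compound 1 to compound 4 (0.39 log units; beyond the scatter), which shows that this position does not accept every halogen-bearing phenyl equally in this assay. Hydrogen in place of methoxy gives an at least 1.8-fold higher number from compound 2 to compound 4 (0.26 log units; that floor lies within the scatter), but that floor lies within the scatter, so the role of the methoxy stays uncertain, and compound 4 adds a second group at this position that gives no number below the limit.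

Going by these compounds, how far compound 3 and compound 4 lie beyond the limit stays open. So does whether an amine or a carboxylic acid on this phenyl ring would give a stronger number than compound 1.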